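Swapping the Silicon Group for a 4-Methylphenyl Ring

A few compounds are considered here, and "the series" means these few. Any claim that something is new, unique, unknown or untested is made for them only; others in the source may bear on it.

Three compounds have been measured so far:
compound 1, `O=C1O[C@H]([C@@H](O)Cn2cc(-c3cccc(O)c3)nn2)C(OCc2ccccc2)=C1OCc1ccccc1`, giving 39300 nM;
compound 2, `O=C1O[C@H]([C@@H](O)Cn2cc(CNS(=O)(=O)c3ccc(F)cc3)nn2)C(OCc2ccccc2)=C1OCc1ccccc1`, giving 25000 nM;
compound 3, `C[Si](C)(C)c1cn(C[C@H](O)[C@H]2OC(=O)C(OCc3ccccc3)=C2OCc2ccccc2)nn1`, giving 22300 nM.

All three numbers come from a functional assay on HeLa cells (Homo sapiens) for antiproliferative activity, read by MTT assay, with a stated time of 72 h; on this read-out higher numbers stand for weaker inhibition and lower numbers for stronger inhibition. Compound 3 shows the lowest of the three numbers, but its gaps to compound 2 and to compound 1 both lie within the scatter, so no ranking among them can be read from these data. Compound 4, `Cc1ccc(-c2cn(C[C@H](O)[C@H]3OC(=O)C(OCc4ccccc4)=C3OCc3ccccc3)nn2)cc1`, has not yet been measured. The change from compound 3 is: a group of 7 heavy atoms (7 carbon; one six-membered aromatic ring of carbon only) in place of a group of 4 heavy atoms (3 carbon, 1 silicon; no ring), on an aromatic carbon. Within the data shown here, the measured step that bears most directly on this is the one from compound 1 to compound 3, which also exchanged a six-membered aromatic ring of carbon only for the silicon-bearing group: a 1.8-fold lower number from compound 1 to compound 3 (0.25 log units; within the scatter). The step of a 1.1-fold lower number from compound 2 to compound 3 (0.05 log units; within the scatter) was of the same small kind. Reversing such an exchange is therefore expected to shift the number little, if anything slightly upward, because compound 1 gave 39300 nM. Compound 4 is estimated at 30000 nM. The expected range for compound 4 runs from 12000 nM to 75000 nM. This estimate for compound 4 means an expected step of a 1.3-fold higher number from compound 3 to compound 4 (0.13 log units; within the scatter).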

Compound 4, half-maximal inhibitory concentration: 25500 nM
Compound 4: the middle estimate sits 1.2-fold (0.07 log units) above what was measured; the measured number falls inside the stated range.
By their numbers in this assay, from the lowest: compounds 3, 2, 4 and 1 (each within the scatter of the next).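

In this assay, exchanging the silicon-bearing group for 4-methylphenyl on this aromatic carbon gives a 1.1-fold higher number from compound 3 to compound 4 (0.06 log units; within the scatter) and so adds a six-membered aromatic ring here with no difference that can be read. The same holds for 4-methylphenyl against (((4-fluorophenyl)sulfonyl)amino)methyl, with a 1.0-fold higher number from compound 2 to compound 4 (0.01 log units; within the scatter) in this comparison, and against 3-hydroxyphenyl, with a 1.5-fold lower number from compound 1 to compound 4 (0.19 log units; within the scatter) in this one, so all four groups on this carbon give numbers that cannot be told apart. No supporting data are available to explain this result.

On these data alone, whether an amine or a carboxylic acid on this carbon would give a step beyond the scatter remains open. All four compounds share the rest of the core, so they also leave open what a change elsewhere in it would do.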